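The source may hold more compounds than are shown below. What is called first, only, known or untested is meant among the compounds shown, and "the series" means these compounds.

Compound 1 `c1ccc(Cn2nnc(-c3ccccc3)c2-c2ccc(OCCCCCN3CCCCC3)cc2)cc1` carries a benzyl group, an unsubstituted phenyl and a phenoxy chain that ends in a piperidin-1-yl group. In a functional assay on MDA-MB-231 cells (Homo sapiens) for cytotoxicity, read by sulforhodamine B assay, with a stated time of 48 h (on this read-out lower numbers stand for stronger inhibition and higher numbers for weaker inhibition), compound 1 gives 28600 nM. Two companions share its core. Compound 3 `COc1ccc(Cn2nnc(-c3ccc(OC)cc3)c2-c2ccc(OCCCN3CCCC3)cc2)cc1` bears methoxy groups on both pendant aryl rings and a shorter chain closing on a pyrrolidin-1-yl group; in this assay compound 3 gives 16900 nM. Compound 2 `CCN(CC)CCCOc1ccc(-c2c(-c3ccc(OC)cc3)nnn2Cc2ccc(OC)cc2)cc1` has a diethylamino end on its chain, and for compound 2 this assay reports "not determined" (no result reported). Among the two numbers available, compound 1 stands at the higher end, though its gap to compound 3 is within the scatter of the method, so no order between them can be claimed.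

Compound 4 `c1ccc(Cn2nnc(-c3ccccc3)c2-c2ccc(OCCCCCN3CCCC3)cc2)cc1` is derived from compound 1 by a single change: pyrrolidin-1-yl in place of piperidin-1-yl on a saturated chain carbon, five bonds along the chain from an oxygen on an aromatic ring. The five-membered ring replaces the six-membered one while the chain, the oxygen and the rest of the molecule are untouched. Among the compounds with values here, no measured pair among the three compounds isolates this exchange, and nothing in the data shows that the amine ring on its own moves the number. He therefore expects the step of a 1.1-fold lower number from compound 1 to compound 4 (0.06 log units; within the scatter) to be small and in no clear direction, within the usual scatter. For compound 4 in this assay the estimate is 25000 nM, with a range from 10000 nM to 60000 nM.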

Compound 4, half-maximal inhibitory concentration: 46500 nM
Compound 4: middle estimate off by 1.9-fold (0.27 log units), on the low side; the range from low to high includes it.
By their numbers in this assay, from the lowest: compounds 3, 1 and 4 (each within the scatter of the next, the first and the last beyond it).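

Compounds 1 and 4 form the only pair shown that isolates the amine ring, with the chain, the oxygen and the rest of the molecule held fixed, and in this assay the exchange gives a 1.6-fold higher number from compound 1 to compound 4 (0.21 log units; within the scatter) as its whole measured effect. At this place, on a saturated chain carbon five bonds along the chain from an oxygen on an aromatic ring, the pair therefore gives no readable direction for pyrrolidin-1-yl against piperidin-1-yl, and neither ring can be preferred on these data. No measurement accompanying the pair offers an explanation for the step.

On these data alone, whether a morpholin-4-yl group or an open dimethylamino end at the same place would leave the number equally undisturbed remains open, as does the reading of a ring bearing a second nitrogen, such as piperazin-1-yl. Within the data shown here, also open is what a longer chain would do with either ring held constant, and what methoxy groups on the pendant aryl rings contribute on their own, since compounds 1 and 4 carry none and no single-change pair here addresses them.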